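The source may hold more compounds than are shown below. What is called first, only, known or untested is meant among the compounds shown, and "the series" means these compounds.

In a functional assay on HL-60 cells (Homo sapiens) for inhibition, read by resazurin assay, with a stated time of 72 h (on this read-out higher numbers stand for weaker inhibition and lower numbers for stronger inhibition), compound 1 (`COc1ccc(C2C(Oc3ccccc3)C(=O)N2c2cc(OC)c(OC)c(OC)c2)cc1`) gives 19 nM and compound 2 (`COc1cc(N2C(=O)C(Oc3ccccc3)C2c2ccc(SC)cc2)cc(OC)c1OC`) gives 388 nM, the higher of the two numbers. Compound 3 (`CCOc1ccc(C2C(Oc3ccccc3)C(=O)N2c2cc(OC)c(OC)c(OC)c2)cc1`) departs from compound 2 by ethoxy in place of methylsulfanyl on an aromatic carbon, with ethoxy in place of methylsulfanyl on an aromatic carbon. For the measured compounds named here, the only measured step bearing on this is large (a 20-fold higher number from compound 1 to compound 2 (1.31 log units; beyond the scatter)) and puts methylsulfanyl in place of methoxy. Ethoxy removes that methylsulfanyl again, so a large step to a lower number is expected (a 6.5-fold lower number from compound 2 to compound 3 (0.81 log units; beyond the scatter)), probably not a full return. Compound 3 is estimated at 60 nM (range 15 nM to 250 nM).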

Compound 3, half-maximal inhibitory concentration: 494 nM
The estimate for compound 3 lay 8.2-fold (0.92 log units) below the measured number, outside the stated range (above it).
By their numbers in this assay, from the lowest: compound 1; then compounds 2 and 3 (each within the scatter of the next).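

In this assay, on an aromatic carbon para to a large group, adding a single methyl to methoxy to give ethoxy has a large effect: a 26-fold higher number from compound 1 to compound 3 (1.41 log units; beyond the scatter). Ethoxy and methylsulfanyl are not separated here: a 1.3-fold higher number from compound 2 to compound 3 (0.10 log units; within the scatter), so among these three groups only the methoxy of compound 1 gives a low number. No measurement here accounts for this.

On these data alone, whether hydroxy or fluorine at this place would match methoxy remains open. As far as these compounds go, whether a longer chain such as propoxy would match ethoxy is also open.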